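This account rests on a few compounds, and the source may have more. Where it says the series, first, only, none or still open, it means among the compounds named here.

In a functional assay on HepG2 cells (Homo sapiens) for antiproliferative activity, read by CCK-8 assay, with a stated time of 72 h (a lower number here means a stronger inhibitor, a higher number a weaker inhibitor), three relatives of the unmeasured compound 4 (`Nc1ccccc1NC(=O)c1ccc(Cn2cnc3c(Nc4cccc(Cl)c4)nc(Cl)nc32)cc1`) already have numbers. Compound 1 (`CCC(C)n1cnc2c(NCc3ccc(C(=O)Nc4ccccc4N)cc3)nc(Cl)nc21`) gives 2990 nM, compound 2 (`Nc1ccccc1NC(=O)c1ccc(Cn2cnc3c(NCc4ccccc4)nc(Cl)nc32)cc1`) gives 7720 nM and compound 3 (`Nc1ccccc1NC(=O)c1ccc(COCNc2nc(Nc3ccccc3)c3ncn(C4CCCC4)c3n2)cc1`) gives 6020 nM. Compound 2 and compound 3 lie within the scatter of each other at the upper end of this small set, while compound 1 has a lower number than compound 2, beyond the scatter.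

Moving from compound 2 to compound 4 puts 3-chlorophenyl in place of benzyl on a nitrogen on an aromatic ring. Going by the values given here, no two measured compounds differ in one place alone, so the data offer no direct precedent for this change. Still, the three numbers span a narrow range, with compound 1 at 2990 nM as the lowest, and a large move would be a departure from them. A small shift toward a lower number, within the scatter, is expected. The estimated step is a 1.5-fold lower number from compound 2 to compound 4 (0.19 log units; within the scatter). For compound 4 the estimated value is 5000 nM, with an expected range from 1800 nM to 14000 nM.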

Compound 4, half-maximal inhibitory concentration: 9800 nM
Compound 4: the middle estimate sits 2.0-fold (0.29 log units) below what was measured; low and high end bracket the measured number.
By their numbers in this assay, from the lowest: compounds 1, 3, 2 and 4 (each within the scatter of the next, the first and the last beyond it).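

In this assay, going by these compounds alone, this is the first pair in the set that differs in one place alone, and it gives a 1.3-fold higher number from compound 2 to compound 4 (0.10 log units; within the scatter) for 3-chlorophenyl in place of benzyl on a nitrogen on an aromatic ring. The change from benzylamino to (3-chlorophenyl)amino therefore does not separate compound 2 from compound 4 in this read-out. Within the data shown here, this single exchange gives the first direct reading at this position, and it shows that this position tolerates the swap without a step beyond the scatter.

Going by these compounds, it remains open whether a different kind of group on this nitrogen, such as an aliphatic amine, a carboxylic acid or a longer chain like phenethyl, would give a step beyond the scatter. On these data alone, it is also open whether the same exchange would read alike on the core of compound 1. No measurement at hand accounts for this result.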